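The source may hold more compounds than are shown below. What is called first, only, known or untested is meant among the compounds shown, and "the series" means these compounds.

Measured so far:
compound 1, `CCCCCCCCCCCCCCCCc1nc(N2CCC2)nc(OC2CCC2)c1O`: 103%
compound 2, `CCCCCCCCCCCCCCc1nc(N2CCC2)nc(N2CCC2)c1O`: 1%

In a functional assay on cells (Lymphocyte, Homo sapiens), read by a luciferase reporter and ATP content, with a stated time of 48 h, tested at 20 uM (a higher number here means a weaker effect of the compound at the concentration tested, a lower number a stronger effect), compound 2 gives 1%, the lower of the two numbers, while compound 1 gives 103%, a gap well beyond the scatter. Compound 3, `CCCCCCCCCCCCCCCCc1nc(N2CCC2)nc(N2CCC2)c1O`, differs from compound 2 by ethyl in place of hydrogen on a saturated chain carbon, ten or more bonds along the chain from an aromatic carbon. Among the measured compounds shown here, no measured pair shows this change alone, so its effect is unknown. The step from a number 5 percentage points higher from compound 2 to compound 3 (within the scatter) is expected to be small, most likely within the scatter, since compound 2 already gives a very low number at 1%. For compound 3 the expected value is 6%, within a range of 0% to 35%.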

Compound 3, a percentage reported as activity, at one concentration (the size of the read-out at that concentration, not a potency): 1%
Beside the measured number, compound 3's estimate is 5 percentage points above it; low and high end bracket the measured number.
By their numbers in this assay, from the lowest: compounds 2 and 3 (each within the scatter of the next); then compound 1.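

In this assay, ethyl in place of hydrogen on a saturated chain carbon, ten or more bonds along the chain from an aromatic carbon, gives no change at the digits printed from compound 2 to compound 3 (within the scatter), so the low number holds across this pair. Among the compounds shown here, compound 3 also gives the first single-place comparison with compound 1: azetidin-1-yl in place of cyclobutyloxy on an aromatic carbon gives a number 102 percentage points lower from compound 1 to compound 3 (beyond the scatter), tying the large gap to that one group. Nothing available explains either step.

Going by these compounds, whether a much shorter chain, such as butyl, would keep the low number remains open. So does whether an open-chain amine such as dimethylamino could take the place of azetidin-1-yl.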